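The compounds below may be only part of what the source reports. "The series", "measured", "known", "first", "only" and "open" are said of these compounds alone.

Measured so far:
Compound 1 `Cc1ccc(F)cc1NC(=O)CN1CCN(c2nnc(Cc3ccccc3)c3ccccc23)CC1`: in a functional assay on HT-29 cells (Homo sapiens) for cytotoxicity, read by MTT assay, with a stated time of 72 h (on this read-out lower numbers stand for stronger inhibition and higher numbers for weaker inhibition), compound 1 gives 171000 nM.
Compound 2 `O=C(CN1CCN(c2nnc(Cc3ccccc3)c3ccccc23)CC1)Nc1ccc(F)c(C(F)(F)F)c1`: in this assay compound 2 gives 4590 nM.

Going by the values given here, compound 2 holds the lowest number of the two; the only neighbour is compound 1, and the step of a 37-fold lower number from compound 1 to compound 2 (1.57 log units; beyond the scatter) separates them. Compound 3 `O=C(CN1CCN(c2nnc(Cc3ccccc3)c3ccccc23)CC1)Nc1ccc(Br)cc1` differs from compound 2 in one place: 4-bromophenyl in place of 4-fluoro-3-(trifluoromethyl)phenyl on an amide-type nitrogen. Among the compounds with values here, the single measured step, a 37-fold lower number from compound 1 to compound 2 (1.57 log units; beyond the scatter), shows that changing the aryl group on the amide-type nitrogen can move the number a long way, but no measured pair tests 4-bromophenyl itself. A moderate rise from compound 2 is expected, a 2.6-fold higher number from compound 2 to compound 3 (0.42 log units; beyond the scatter), with wide uncertainty. Compound 3 is estimated at 12000 nM in this assay, within 3000 nM to 50000 nM.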

Compound 3, half-maximal inhibitory concentration: 60200 nM
Beside the measured number, compound 3's estimate is 5.0-fold (0.70 log units) below it; the measured number lies above the stated range.
By their numbers in this assay, from the lowest: compound 2; then compound 3; then compound 1.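

In this assay the change to 4-bromophenyl on the amide-type nitrogen gives a 13-fold higher number from compound 2 to compound 3 (1.12 log units; beyond the scatter) and so gives up most of the low number of compound 2. Against the other aryl group it gives only a 2.8-fold lower number from compound 1 to compound 3 (0.45 log units; beyond the scatter) and so places compound 3 between the two earlier compounds. No measurement here accounts for the difference between these aryl groups.

From the compounds shown here alone, whether the fluorine or the trifluoromethyl of compound 2 carries its low number stays open. So does the effect of a plain phenyl, or of a phenyl bearing an amine or a carboxylic acid, on this nitrogen.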